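Trimming the Methylsulfonyl Group on an Aromatic Carbon

A few compounds are considered here, and "the series" means these few. Any claim that something is new, unique, unknown or untested is made for them only; others in the source may bear on it.

Compound 1, `CC(C)OC(=O)N1CCC(Oc2ncnc3c2CCN3c2ccc(S(C)(=O)=O)cn2)CC1`: 111%
Compound 2, `CC(C)OC(=O)N1CCC(Oc2ncnc3c2CCN3c2ccc(S(C)(=O)=O)c(F)c2)CC1`: 109%

In a functional assay on CHO-K1 cells with Glucose-dependent insulinotropic receptor (Homo sapiens) as the target, read by a luciferase reporter, with a stated time of 5 h (a lower number here means a smaller maximal response, a higher number a larger maximal response), compound 1 gives 111%, and compound 2 gives 109%. Within the data shown here, the only measured step is a number 2 percentage points lower from compound 1 to compound 2 (within the scatter), so compound 2 stands level with compound 1 within the scatter, and both reach a maximal response close to that of the reference.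

Compound 3, `CC(C)OC(=O)N1CCC(Oc2ncnc3c2CCN3c2ccc([S@@+](C)[O-])c(F)c2)CC1`, has not yet been measured in this assay. It differs from compound 2 in one place: a group of 3 heavy atoms (1 carbon, 1 oxygen, 1 sulfur; no ring) in place of a group of 4 heavy atoms (1 carbon, 2 oxygen, 1 sulfur; no ring), on an aromatic carbon. Among the measured compounds shown here, the measured step from compound 1 to compound 2 changes the ring on the nitrogen, not the group on the aromatic carbon, so it does not bear on this change; there is no measured step for a change of this kind. What the data do show is that compound 2, with the methylsulfonyl group, gives a maximal response near the reference. For the measured compounds named here, with no step to build on, compound 3 is expected to stay near compound 2, with a step of a number 9 percentage points lower from compound 2 to compound 3 (within the scatter), and the expected value for compound 3 is 100%, with a range from 70% to 120%.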

Compound 3, largest response reached (reported as percent of maximum), in percent of the reference or control that the assay uses: 155%
The estimate for compound 3 lay 55 percentage points below the measured number; measured number outside the range, above it.
By their numbers in this assay, from the lowest: compounds 2 and 1 (each within the scatter of the next); then compound 3.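

Replacing the methylsulfonyl group on this aromatic carbon with the group of 3 heavy atoms, which carries 1 defined stereocentre, gives a number 46 percentage points higher from compound 2 to compound 3 (beyond the scatter) in this assay, whereas the change of ring on the nitrogen gave only a number 2 percentage points lower from compound 1 to compound 2 (within the scatter). This shows that the maximal response is sensitive to the group at this place, ortho to a fluoro group and para to a large group, and that it can rise well beyond the level shared by the two methylsulfonyl compounds; the comparison across both changes, a number 44 percentage points higher from compound 1 to compound 3 (beyond the scatter), likewise sets compound 3 apart from compound 1. No measurement given here accounts for this rise.

The compounds shown leave open whether the opposite arrangement at the stereocentre would give the same maximal response, and whether the new group would have a similar effect on the 5-(methylsulfonyl)pyridin-2-yl ring's counterpart without the fluoro group. They also leave open how a methylthio group or an amine at this aromatic carbon would compare with the methylsulfonyl group and with the group in compound 3.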